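Swapping the aryl group for a larger bicyclic piece

The compounds below may be only part of what the source reports. "The series", "measured", "known", "first", "only" and "open" are said of these compounds alone.

Of the compounds shown here, three of one shared core have been tested in an ADME assay on microsomes from liver (Rattus norvegicus) for metabolic stability, read by LC-MS, with a stated time of 10 min, tested at 0.5 uM; a higher number here means that more of the compound is left, a lower number that less of the compound is left. Compound 1 `c1ccc2c(c1)CN[C@@H](CN(CC[C@H]1CCCNC1)[C@H]1CCCc3cccnc31)C2` gives 55%. Compound 2 `c1cnc(CN(CCCN2CCNCC2)[C@H]2CCCc3cccnc32)nc1` gives 68%, and compound 3 `CC(C)N1CCN(CCCN(C[C@H]2Cc3ccccc3CN2)[C@H]2CCCc3cccnc32)CC1` gives 4%. Compound 2 stands highest of the three; its nearest neighbour is compound 1, and compound 3 lies furthest from it, both gaps beyond the scatter. Within the data shown here, the one step between compounds that differ in a single place runs a number 51 percentage points lower from compound 1 to compound 3 (beyond the scatter), a large drop.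

Compound 4 `c1cnc2c(c1)CN[C@H](CN(CCCN1CCNCC1)[C@H]1CCCc3cccnc31)C2` has not yet been measured in this assay. It differs from compound 2 in one place: a group of 10 heavy atoms (8 carbon, 2 nitrogen; one six-membered non-aromatic ring with 1 hetero atom, one six-membered aromatic ring with 1 hetero atom) in place of a group of 6 heavy atoms (4 carbon, 2 nitrogen; one six-membered aromatic ring with 2 hetero atoms), on a saturated chain carbon bound to an amine nitrogen.

Among the measured compounds shown here, no measured step matches this change directly. The step from compound 1 to compound 3 altered the chain end, not the group on the carbon bound to the amine nitrogen, so it bears only loosely here. Compound 1, which carries a related bicyclic group, sits below compound 2, whereas compound 3, which carries a different chain end, is far lower. Compound 4 is therefore expected to fall modestly below compound 2, a step of a number 18 percentage points lower from compound 2 to compound 4 (beyond the scatter), with the estimate for compound 4 at 50% and a range from 25% to 75%.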

Compound 4, percent of the compound remaining: 87%
Estimate against measurement, compound 4: 37 percentage points below; the measured number lies above the stated range.
By their numbers in this assay, from the lowest: compound 3; then compound 1; then compound 2; then compound 4.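

Among these compounds, this is the first measured change at this place, a saturated chain carbon bound to an amine nitrogen, and in this assay the swap of pyrimidin-2-yl for the group of 10 heavy atoms gives a number 19 percentage points higher from compound 2 to compound 4 (beyond the scatter) with the rest of the molecule held the same. So at least in this pair, a larger group with one six-membered non-aromatic ring and one six-membered aromatic ring leaves more of the compound remaining, not less, even though the entering group also brings 1 hydrogen-bond donor and 1 defined stereocentre. Among the compounds shown here, nothing measured here accounts for this rise, so the single step records the size of the effect and not its origin.

From the compounds shown here alone, whether the gain comes from the whole group or from one part of it stays open, and a simple phenyl or pyridin-2-yl at this place would help to separate size from the ring nitrogen atoms. Also open, going by these compounds, is whether the opposite form of the defined stereocentre would behave alike, and whether the same swap would hold with another chain end, such as a piperidin-4-yl group.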